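This account rests on a few compounds, and the source may have more. Where it says the series, first, only, none or still open, it means among the compounds named here.

Compound 1 `CN(C)CCCNc1nc(-c2ccc(NC(=O)Nc3ccccc3F)cc2)nc2ccsc12`: in a functional assay on MKN-45 cells (Homo sapiens) for cytotoxicity, read by MTT assay, with a stated time of 72 h (a lower number here means a stronger inhibitor, a higher number a weaker inhibitor), compound 1 gives 730 nM.
Compound 2 `CN(C)CCCNc1nc(-c2ccc(NC(=O)Nc3ccc(F)cc3)cc2)nc2c(Cl)c(Cl)sc12`: compound 2 gives 1120 nM.
Compound 3 `CN(C)CCCNc1nc(-c2ccc(NC(=O)Nc3ccccc3Cl)cc2)nc2ccsc12`: compound 3 gives 690 nM.

For the measured compounds named here, of these three numbers, the one for compound 3 is the lowest, yet its gap to compound 1 and its gap to compound 2 both fall inside the usual scatter of this measurement, so the three compounds cannot be told apart on these data. Going by the values given here, the one step measured between two compounds that differ in a single place, a 1.1-fold lower number from compound 1 to compound 3 (0.02 log units; within the scatter), swaps fluoro for chloro on the same ring and stays within the scatter.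

Compound 4 `CN(C)CCCNc1nc(-c2ccc(NC(=O)Nc3ccc(Cl)cc3Cl)cc2)nc2ccsc12` differs from compound 3 by chloro in place of hydrogen on an aromatic carbon. Among the compounds with values here, no measured pair shows what a second chloro on this ring does; the only step that touches the ring at all is the small one from compound 1 to compound 3, which gives no reason to expect a move beyond the scatter in either direction. The estimate for compound 4 is therefore a step of a 1.2-fold lower number from compound 3 to compound 4 (0.06 log units; within the scatter) relative to compound 3, which is expected to place compound 4 near 600 nM, with a range from 250 nM to 1500 nM.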

Compound 4, half-maximal inhibitory concentration: 2270 nM
For compound 4 the middle estimate is 3.8-fold (0.58 log units) below the measured one; the whole stated range lies below it.
By their numbers in this assay, from the lowest: compounds 3, 1 and 2 (each within the scatter of the next); then compound 4.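

In this assay, for the compounds shown here, adding a chloro to the ring that already carries one, so that 2-chlorophenyl becomes 2,4-dichlorophenyl, gives a 3.3-fold higher number from compound 3 to compound 4 (0.52 log units; beyond the scatter): the first single-place step to lie beyond the scatter, and it points towards a weaker inhibitor. The earlier step, a 1.1-fold lower number from compound 1 to compound 3 (0.02 log units; within the scatter), changed only the halogen already on this ring and showed no measurable effect, so this ring is not indifferent to every change; a new chloro at the carbon para to a large group does register. The step of a 3.1-fold higher number from compound 1 to compound 4 (0.49 log units; beyond the scatter), 2,4-dichlorophenyl in place of 2-fluorophenyl, is also beyond the scatter and points the same way, but no measurement shown here accounts for the loss.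

From the compounds shown here alone, what stays open is whether the loss belongs to chloro itself or to any added group at this carbon, which a methyl, a methoxy or an amine there would help to settle. Going by these compounds, it is also open whether a lone 4-chlorophenyl group would behave like 2,4-dichlorophenyl, or whether the loss needs both chloro groups on the ring together.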